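A Swapped Ethenyl Group on Compound 2

This account rests on a few compounds, and the source may have more. Where it says the series, first, only, none or still open, it means among the compounds named here.

In a functional assay on SK-N-SH cells (Homo sapiens) for cytotoxicity, read by MTT assay, with a stated time of 48 h (on this read-out lower numbers stand for stronger inhibition and higher numbers for weaker inhibition), compound 1 (`COc1ccc(/C=C/c2cc(OC)c(OC)c(OC)c2-c2ccc(Cl)cc2)cc1`) gives 15000 nM and compound 3 (`C=C(c1ccc(OC)cc1)c1cc(OC)c(OC)c(OC)c1-c1ccc(Cl)cc1`) gives 15000 nM. Compound 2 (`COc1cc(/C=C/c2ccccc2)c(-c2ccccc2)c(OC)c1OC`) gives 63000 nM, the highest of the three numbers, and its gap to each of the others lies beyond the scatter. Compound 4 (`C=C(c1ccc(C)cc1)c1cc(OC)c(OC)c(OC)c1-c1ccccc1`) is still unmeasured and differs from compound 2 as follows: 1-(4-methylphenyl)ethenyl in place of 2-phenylethenyl on an aromatic carbon. Among the compounds with values here, no measured pair isolates this change. A modest step to a lower number is nevertheless expected in this assay, as compound 3, which carries an ethenyl link of the same kind, stands at 15000 nM. The estimated step is a 2.3-fold lower number from compound 2 to compound 4 (0.35 log units; beyond the scatter). The value expected for compound 4 is 28000 nM, within an estimated range of 10000 nM to 70000 nM.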

Compound 4, half-maximal inhibitory concentration: 31000 nM
The estimate for compound 4 lay 1.1-fold (0.04 log units) below the measured number; measured number inside the range.
By their numbers in this assay, from the lowest: compounds 1 and 3 (each within the scatter of the next); then compound 4; then compound 2.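

In this assay, 1-(4-methylphenyl)ethenyl in place of 2-phenylethenyl, on the aromatic carbon ortho to a phenyl group, gives a 2.0-fold lower number from compound 2 to compound 4 (0.31 log units; beyond the scatter). Within the data shown here, this is the only measured pair that isolates a change at this position, and it shows that the number responds to the swap there, though modestly. No measurement at hand explains the step. The compounds shown do not separate the moved attachment of the ring from the added methyl. They also leave open how an amine or a carboxylic acid on that ring would read.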